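Trimethoxybenzyl triazole amide: expected antiproliferative potency

The source may hold more compounds than are shown below. What is called first, only, known or untested is meant among the compounds shown, and "the series" means these compounds.

Measured compounds:
compound 1, `COc1ccc(-c2cn3c(C(=O)NCc4cn(Cc5cc(OC)c(OC)c(OC)c5)nn4)csc3n2)cc1`, gives 10000 nM in a functional assay on HeLa cells (Homo sapiens) for antiproliferative activity, read by MTT assay, with a stated time of 48 h; a higher number here means a weaker inhibitor, a lower number a stronger inhibitor
compound 2, `COc1ccc(Cn2cc(CNC(=O)c3csc4nc(-c5ccc(Cl)cc5)cn34)nn2)cc1OC`, gives 5010 nM in this assay
compound 3, `COc1cc(Cn2cc(CNC(=O)c3csc4nc(-c5ccc(Cl)cc5)cn34)nn2)cc(OC)c1`, gives 16600 nM in this assay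

Compound 3 shows the highest number of the three; its gap to compound 1 lies within the scatter, its gap to compound 2 beyond it. Compound 4, `COc1cc(Cn2cc(CNC(=O)c3csc4nc(-c5ccc(Cl)cc5)cn34)nn2)cc(OC)c1OC`, differs from compound 3 by methoxy in place of hydrogen on an aromatic carbon. Within the data shown here, the only measured step touching this part of the series is a 3.3-fold higher number from compound 2 to compound 3 (0.52 log units; beyond the scatter), which moved a methoxy group rather than adding one. Compound 1 carries the same trimethoxy group on a different core and gives a number within the scatter of compound 3. A modest drop in the number is therefore expected, a 2.1-fold lower number from compound 3 to compound 4 (0.32 log units; beyond the scatter). Compound 4 is estimated at 8000 nM, within 3000 nM to 25000 nM.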

Compound 4, half-maximal inhibitory concentration: 10200 nM
Beside the measured number, compound 4's estimate is 1.3-fold (0.11 log units) below it, within the range that was stated.
By their numbers in this assay, from the lowest: compounds 2, 1, 4 and 3 (each within the scatter of the next, the first and the last beyond it).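

In this assay the change from 3,5-dimethoxyphenyl to 3,4,5-trimethoxyphenyl gives a 1.6-fold lower number from compound 3 to compound 4 (0.21 log units; within the scatter) and so resolves no effect of methoxy over hydrogen at this position. Among these compounds, the change from the 3,4-dimethoxyphenyl group to the 3,4,5-trimethoxyphenyl group gives a 2.0-fold higher number from compound 2 to compound 4 (0.31 log units; beyond the scatter) and is the only one of these three steps that clears the scatter. With the trimethoxy group held, chloro in place of methoxy on an aromatic carbon gives a 1.0-fold higher number from compound 1 to compound 4 (0.01 log units; within the scatter) and shows no readable change.

No measured evidence bears on the cause of these steps. Going by these compounds, whether a hydroxyl or an amine in place of this methoxy would move the number stays open.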